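The Same Small Change on Two Different Cores

A few compounds are considered here, and "the series" means these few. Any claim that something is new, unique, unknown or untested is made for them only; others in the source may bear on it.

Compound 1, `CSc1nnc(-c2cccc3ccccc23)n1C`, in a functional assay on the whole organism for antagonist activity, with Mus musculus as the target (a higher number here means that more compound is needed for the effect, a lower number that less compound is needed), gives > 200 mg/kg, which is a limit of the assay and not a number.
Compound 2, `Cn1c(-c2cccc3ccccc23)nnc1[S+](C)[O-]`, in this assay gives > 200 mg/kg, again a limit.
For the measured compounds named here, compound 3, `CSc1nnc(-c2ccccc2F)n1C`, in this assay gives 8.8 mg/kg, the only number among the three.

Compound 2 arises from compound 1 by a group of 3 heavy atoms (1 carbon, 1 oxygen, 1 sulfur; no ring) in place of a group of 2 heavy atoms (1 carbon, 1 sulfur; no ring), on an aromatic carbon. Because both ends of this pair sit at the limit of > 200 mg/kg in this assay, at which 2 of the 3 values shown sit, the step that the two limits leave unreadable from compound 1 to compound 2 cannot be read. The difference between the core of compound 1 and the core of compound 3 is not broken down here.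

Compound 4, `Cn1c(-c2ccccc2F)nnc1[S+](C)[O-]`, has not yet been measured. It arises from compound 3 by a group of 3 heavy atoms (1 carbon, 1 oxygen, 1 sulfur; no ring) in place of a group of 2 heavy atoms (1 carbon, 1 sulfur; no ring), on an aromatic carbon. Going by the values given here, this is the same kind of change as the one from compound 1 to compound 2, carried out on the core of compound 3 instead of the core of compound 1.

The only anchor for an expectation is compound 3, whose value of 8.8 mg/kg in this assay is a number, and the step seen on the other core gives no readable size. For compound 4 the step of a 1.7-fold higher number from compound 3 to compound 4 (0.23 log units; within the scatter) is therefore expected to be modest, leaning toward a higher dose. For compound 4 in this assay the estimate is 15 mg/kg, with a plausible span from 4 mg/kg to 60 mg/kg.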

Compound 4, dose for half-maximal effect: 20 mg/kg
Compound 4: the middle estimate sits 1.3-fold (0.12 log units) below what was measured; measured number inside the range.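

In this assay, replacing the methylsulfanyl group of the core of compound 3 with the group that also carries an oxygen gives a 2.3-fold higher number from compound 3 to compound 4 (0.36 log units; beyond the scatter), so more compound is needed after the change, though the step is modest and compound 4 still gives a measurable dose. The same change on the core of compound 1 cannot be read, since both compounds of that pair give a limit of the assay and not a number: the limit of > 200 mg/kg in this assay, at which 2 of the 4 values shown sit.
This pair therefore gives the size of the change on one core only; it does not show that the change would have the same size, or even the same direction, on another core, and a single readable step makes no rule for the series.

The compounds shown leave open what other groups at this same place would do, such as an amine or a longer chain like ethylsulfanyl, and whether a methylsulfonyl group would move the dose further in the same direction. They also leave open how the change would behave on a core carrying chlorine in place of fluorine, where numbers at both ends of the pair could give a second readable step to set beside the first.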